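The compounds below may be only part of what the source reports. "The series", "measured", "known", "first", "only" and "open" are said of these compounds alone.

In a functional assay on the whole organism with Mus musculus as the target (a lower number here means that less compound is needed, a higher number that more compound is needed for the effect), compound 1 `CCNc1c(C)c(C)c2c(c1C)CC(C)(C)O2` gives 38.9 mg/kg and compound 2 `CCCNc1c(C)c(C)c2c(c1C)CC(C)(C)O2` gives 51.1 mg/kg. Among the compounds with values here, these two numbers lie within the scatter of each other, so compound 2 stands level with its only measured neighbour. Within the data shown here, the one measured step, a 1.3-fold higher number from compound 1 to compound 2 (0.12 log units; within the scatter), is a methyl in place of hydrogen on a saturated chain carbon.

Compound 3 `Cc1c(C)c2c(c(C)c1Nc1cccnc1)CC(C)(C)O2` carries pyridin-3-yl in place of propyl on a nitrogen on an aromatic ring. Among the measured compounds shown here, this swaps a chain for a ring, so it is a larger edit than the measured step, and no measured compound has a ring at that nitrogen. The data therefore favour no direction, and the expectation in this assay is a step no larger than the scatter, held with wide uncertainty: a 1.1-fold lower number from compound 2 to compound 3 (0.06 log units; within the scatter). For compound 3 the expected value is 45 mg/kg, with an estimated range from 14 mg/kg to 140 mg/kg.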

Compound 3, dose for 50% inhibition: > 50 mg/kg
Compound 3: only a limit was reported; the forecaster's own chance of this, stated with the estimate: 10%; middle value at least 1.1-fold (0.04 log units) away from the limit.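

In this assay compound 3 gives only a limit of the assay, not a number: the limit of > 50 mg/kg in this assay, at which 1 of the 3 values shown sits. Within the data shown here, the step from compound 2 to compound 3 cannot be read, and the one readable step, an at least 1.2-fold higher number from compound 1 to compound 3 (0.10 log units; that floor lies within the scatter), has a floor that still lies within the scatter. Even so, this first ring on the nitrogen, pyridin-3-yl, gives no sign of the lower number that would mean less compound is needed than with the ethyl and propyl chains.

As far as these compounds go, how far the true value of compound 3 lies past its limit remains open. Also open, from the compounds shown here alone, is whether the ring nitrogen of pyridin-3-yl matters, which a plain phenyl on the same nitrogen would help to settle, and how a longer chain such as butyl would read in this assay.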